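Methoxy to Methyl: Shifting the Benzyl Group's Substituent

This account rests on a few compounds, and the source may have more. Where it says the series, first, only, none or still open, it means among the compounds named here.

Measured so far:
- compound 1, `Cc1ccccc1Cc1cnc(CCc2ccc(-c3ccccc3C(=O)O)cc2)[nH]1`: 127 nM
- compound 2, `COc1ccc(Cc2cnc(CCc3ccc(-c4ccccc4C(=O)O)cc3)[nH]2)cc1`: 5360 nM

For the measured compounds named here, in an in vitro functional assay on cells for agonist activity at Bombesin receptor subtype-3 (Homo sapiens), read by luminescence and calcium flux (a lower number here means that less compound is needed, a higher number that more compound is needed for the effect), compound 2 gives the higher of the two numbers, with compound 1 the only comparison, at 127 nM. Going by the values given here, the step of a 42-fold higher number from compound 1 to compound 2 (1.63 log units; beyond the scatter) is the one measured change that bears on what follows. Compound 3, `Cc1cccc(Cc2cnc(CCc3ccc(-c4ccccc4C(=O)O)cc3)[nH]2)c1`, differs from compound 2 by 3-methylphenyl in place of 4-methoxyphenyl on a saturated chain carbon bound to an aromatic carbon. Since swapping a methylphenyl for the methoxyphenyl cost so much in the measured step, reversing to a methylphenyl is expected to recover part of that loss, though the methyl now sits elsewhere on the ring, so only part. Compound 3 is expected at 800 nM (range 200 nM to 3500 nM), a step of a 6.7-fold lower number from compound 2 to compound 3 (0.83 log units; beyond the scatter).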

Compound 3, half-maximal effective concentration: 4310 nM
For compound 3 the middle estimate is 5.4-fold (0.73 log units) below the measured one; the measured number lies above the stated range.
By their numbers in this assay, from the lowest: compound 1; then compounds 3 and 2 (each within the scatter of the next).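

In this assay, the 3-methylphenyl group gives a 1.2-fold lower number from compound 2 to compound 3 (0.09 log units; within the scatter), so at this place it cannot be told apart from 4-methoxyphenyl. The other comparison is far larger, with a 34-fold higher number from compound 1 to compound 3 (1.53 log units; beyond the scatter), so having a methylphenyl group here is not enough to give the low number of compound 1. Among these three compounds, only the one with 2-methylphenyl stands apart. Still open, going by these compounds, is whether an ethyl group or a chlorine atom in place of the methyl of compound 1 would keep that low number. Nothing available here gives a reason for these results.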